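A few compounds are considered here, and "the series" means these few. Any claim that something is new, unique, unknown or untested is made for them only; others in the source may bear on it.

Measured compounds:
compound 1 `COc1ccc(-c2[nH]c3ccccc3c2/C=C(\C#N)S(=O)(=O)c2ccccc2)cc1` — 4800 nM
compound 2 `COc1ccc(-c2[nH]c3ccc(OC)cc3c2/C=C(\C#N)S(=O)(=O)c2ccccc2)cc1` — 5000 nM

In a functional assay on TK-10 cells (Homo sapiens) for inhibition, read by sulforhodamine B assay, with a stated time of 48 h (on this read-out lower numbers stand for stronger inhibition of growth and higher numbers for weaker inhibition of growth), compound 1 gives 4800 nM and compound 2 gives 5000 nM; the two stand at the same level, the step being a 1.0-fold higher number from compound 1 to compound 2 (0.02 log units; within the scatter). Compound 3 `N#C/C(=C\c1c(-c2ccccc2)[nH]c2ccccc12)S(=O)(=O)c1ccccc1` differs from compound 1 by hydrogen in place of methoxy on an aromatic carbon. Among the measured compounds shown here, the only measured step that bears on this is the one where a methoxy entered on an aromatic carbon, which gave a 1.0-fold higher number from compound 1 to compound 2 (0.02 log units; within the scatter). Removing a methoxy from an aromatic carbon is therefore expected to leave the number where it is, with no step beyond the scatter. Compound 3 is estimated at 5000 nM (range 2500 nM to 10000 nM), an expected step of a 1.0-fold higher number from compound 1 to compound 3 (0.02 log units; within the scatter).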

Compound 3, concentration for 50% growth inhibition: 5600 nM
Beside the measured number, compound 3's estimate is 1.1-fold (0.05 log units) below it; the measured number falls inside the stated range.
By their numbers in this assay, from the lowest: compounds 1, 2 and 3 (each within the scatter of the next).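

In this assay, the change from 4-methoxyphenyl to phenyl gives a 1.2-fold higher number from compound 1 to compound 3 (0.07 log units; within the scatter), so compound 1 and compound 3 stand at the same level. At this place, para to a large group, the methoxy is therefore not required to hold that level. Nothing at hand explains this flat result.

The compounds shown carry only methoxy or hydrogen at this place, so it remains open whether an amine, a carboxylic acid or a longer alkoxy chain there would move the number. Also open, on these data alone, is whether changes elsewhere on the shared core would do so.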